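Pyridyl nitrogen repositioning on the alkyne arm

This account rests on a few compounds, and the source may have more. Where it says the series, first, only, none or still open, it means among the compounds named here.

The two measured compounds share one core and differ only in the pyridyl group on the triple-bonded carbon. Compound 1 `Cc1ccc(-n2nccn2)c(C(=O)N2C[C@H](C#Cc3ccc(CO)nc3)CC[C@H]2C)c1` gives 339 nM in an assay on cells for binding affinity to Orexin/Hypocretin receptor type 1 (Homo sapiens), read by radioligand binding; a higher number here means a weaker inhibitor, a lower number a stronger inhibitor. Compound 2 `Cc1ccc(-n2nccn2)c(C(=O)N2C[C@H](C#Cc3ccc(CO)cn3)CC[C@H]2C)c1` gives 211 nM in this assay. Within the data shown here, the single measured step, a 1.6-fold lower number from compound 1 to compound 2 (0.21 log units; within the scatter), rearranges the ring nitrogen and the hydroxymethyl group within the same ring. Compound 2 thus holds the smaller of the two numbers in this assay, but the gap to compound 1 lies inside the scatter, so the two are not separable.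

Compound 3 `Cc1ccc(-n2nccn2)c(C(=O)N2C[C@H](C#Cc3cncc(CO)c3)CC[C@H]2C)c1` is not yet measured in this assay. Its difference from compound 2 is 5-(hydroxymethyl)pyridin-3-yl in place of 5-(hydroxymethyl)pyridin-2-yl on a triple-bonded carbon. Among the measured compounds shown here, the only step that bears on this change is again a rearrangement of the same atoms within the pyridine ring, and that step, a 1.6-fold lower number from compound 1 to compound 2 (0.21 log units; within the scatter), stayed within the scatter. No other comparison is available. The expectation for compound 3 in this assay is therefore a step of a 1.2-fold higher number from compound 2 to compound 3 (0.07 log units; within the scatter), no movement beyond the scatter. Compound 3 is estimated at 250 nM, with a range from 100 nM to 650 nM.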

Compound 3, inhibition constant: 108 nM
The estimate for compound 3 lay 2.3-fold (0.36 log units) above the measured number, and the stated range covers the measured number.
By their numbers in this assay, from the lowest: compounds 3, 2 and 1 (each within the scatter of the next, the first and the last beyond it).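

Working notes: in this assay, the pyridyl group on the triple-bonded carbon now shows its first separation beyond the scatter, with a 3.1-fold lower number from compound 1 to compound 3 (0.50 log units; beyond the scatter) for 5-(hydroxymethyl)pyridin-3-yl in place of 6-(hydroxymethyl)pyridin-3-yl. The two groups carry the same atoms and the same counts, so how those atoms are joined within the ring is enough to shift the number at this position, although the other step, a 2.0-fold lower number from compound 2 to compound 3 (0.29 log units; within the scatter), stays within the scatter and leaves compound 2 unseparated from compound 3, just as compound 2 is unseparated from compound 1. No supporting data accompany these numbers that would account for the separation between compound 1 and compound 3.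

Open, from the compounds shown here alone, is whether the hydroxymethyl group itself contributes to the numbers in this assay, or whether the same ring arrangement would hold with an aminomethyl group, a carboxylic acid or a longer hydroxyalkyl chain in its place. Also open, going by these compounds, is how a plain phenyl ring on the triple-bonded carbon would compare with these three pyridyl groups, and whether the separation seen here would carry over to any other core.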